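Series notes: from compound 2 to compound 3

The compounds below may be only part of what the source reports. "The series", "measured", "known", "first", "only" and "open" are said of these compounds alone.

In a toxicity assay on cells (Fibroblast, Homo sapiens) for cytotoxicity (on this read-out lower numbers stand for stronger inhibition and higher numbers for weaker inhibition), compound 1 `CC(/C=C/C1=CCCCC1(C)C)=C\C=C\C(C)=C\COC(=O)c1cc(O)ccc1O` gives 14000 nM and compound 2 `COc1cccc(C(=O)OC/C=C(C)/C=C/C=C(C)/C=C/C2=CCCCC2(C)C)c1O` gives 27000 nM. These two values lie within the scatter of each other, so compound 2 cannot be separated from compound 1 on the numbers available.

Compound 3 `COc1cc(O)c(C(=O)OC/C=C(C)/C=C/C=C(C)/C=C/C2=CCCCC2(C)C)c(O)c1` is the next to be read. Its change from compound 2 is a group of 10 heavy atoms (7 carbon, 3 oxygen; one six-membered aromatic ring of carbon only) in place of a group of 9 heavy atoms (7 carbon, 2 oxygen; one six-membered aromatic ring of carbon only), on a carbonyl carbon. The 2-hydroxy-3-methoxyphenyl leaves, and the new group takes its place on the same carbonyl carbon.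

Going by the values given here, only one measured step bears on this change. It is a 1.9-fold higher number from compound 1 to compound 2 (0.29 log units; within the scatter), which also exchanges the group on the carbonyl carbon and stays within the scatter. Among the compounds with values here, no measured compound carries the entering group, so this single step is weak support, and the range has to stay wide.

No step beyond the scatter is expected in this assay, and the expected move is a 1.4-fold lower number from compound 2 to compound 3 (0.13 log units; within the scatter). For compound 3 the estimated value is 20000 nM, with an expected range from 9000 nM to 45000 nM.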

Compound 3, half-maximal inhibitory concentration: 14000 nM
For compound 3 the middle estimate is 1.4-fold (0.15 log units) above the measured one, and the stated range covers the measured number.
By their numbers in this assay, from the lowest: compounds 1, 3 and 2 (each within the scatter of the next).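

In this assay, exchanging the group on the carbonyl carbon gives a 1.9-fold lower number from compound 2 to compound 3 (0.29 log units; within the scatter), and the comparison with the other dihydroxy-substituted compound gives no change at the digits printed from compound 1 to compound 3 (within the scatter). The position has now carried three different groups, the entering one having 10 heavy atoms, 2 hydrogen-bond donors and 3 hydrogen-bond acceptors against 9, 1 and 2 for the 2-hydroxy-3-methoxyphenyl, and neither new step leaves the scatter, so the added atoms give no separable difference and compound 1, compound 2 and compound 3 cannot be put in any order on this read-out. No supporting measurement is available to explain why these numbers stay together.

All three groups shown are phenyl rings carrying hydroxy groups, so it stays open whether this position can produce a step beyond the scatter at all, for instance with an amine or a carboxylic acid on the ring, or with a plain alkyl chain in place of the ring. From the compounds shown here alone, the contribution of the shared core to the numbers in this assay also stays open, since that part is the same in all three compounds.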